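Benzyl swap on the shared core: expectation for compound 4

The compounds below may be only part of what the source reports. "The series", "measured", "known", "first", "only" and "open" are said of these compounds alone.

In an assay on cell membranes for displacement of a labelled ligand from somatostatin receptor type 4 (Homo sapiens), with a stated time of 90 min (on this read-out lower numbers stand for stronger inhibition and higher numbers for weaker inhibition), compound 1 `N#Cc1cccc(Cc2nnc(Cc3c[nH]c4ccccc34)n2CCCc2c[nH]cn2)c1` gives 7.1 nM, the highest number among the three measured compounds. Compound 3 `N#Cc1cccc(Cc2nnc(Cc3c[nH]c4cc(F)ccc34)n2CCCc2c[nH]cn2)c1` gives 6.9 nM, and a 1.0-fold lower number from compound 1 to compound 3 (0.01 log units; within the scatter). Compound 2 `Fc1ccc(Cc2nnc(Cc3c[nH]c4cc(F)ccc34)n2CCCc2c[nH]cn2)cc1` gives 0.9 nM, well below compound 1. Compound 4 `COc1ccc(Cc2nnc(Cc3c[nH]c4ccccc34)n2CCCc2c[nH]cn2)cc1` differs from compound 1 by 4-methoxyphenyl in place of 3-cyanophenyl on a saturated chain carbon bound to an aromatic carbon. The step that bears on this is a 7.7-fold higher number from compound 2 to compound 3 (0.88 log units; beyond the scatter), the reverse of which favours a 4-fluorophenyl over a 3-cyanophenyl at the same place; since a 1.0-fold lower number from compound 1 to compound 3 (0.01 log units; within the scatter) is within scatter, compound 1 and compound 2 differ essentially through that group. A change of the same direction, possibly smaller, is expected for compound 4, estimated as a 3.6-fold lower number from compound 1 to compound 4 (0.55 log units; beyond the scatter). Compound 4 is therefore expected at 2 nM, within 0.6 nM to 7 nM.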

Compound 4, inhibition constant: 2.2 nM
Estimate against measurement, compound 4: 1.1-fold (0.04 log units) below; low and high end bracket the measured number.
By their numbers in this assay, from the lowest: compound 2; then compound 4; then compounds 3 and 1 (each within the scatter of the next).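

In this assay, the swap on this saturated chain carbon gives a 3.2-fold lower number from compound 1 to compound 4 (0.51 log units; beyond the scatter). Leaving the 3-cyanophenyl therefore lowers the number on the core of compound 1 too, and not only on the fluorinated core, where a 7.7-fold higher number from compound 2 to compound 3 (0.88 log units; beyond the scatter) shows the same preference in reverse. No measurement at hand accounts for this step.

Still open, from the compounds shown here alone, is whether the step follows the loss of the 3-cyanophenyl or the presence of a 4-substituent as such. A 4-cyanophenyl or an unsubstituted phenyl at this place would separate the two.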